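The source may hold more compounds than are shown below. What is called first, only, known or untested is meant among the compounds shown, and "the series" means these compounds.

Measured in a functional assay on MCF7 cells (Homo sapiens) for inhibition; a higher number here means a weaker inhibitor, a lower number a stronger inhibitor:
compound 1 `COc1ccc(-c2nc3ccccc3s2)cc1OC`: 52700 nM
compound 2 `COc1ccc(-c2nc3cc(Cl)ccc3s2)cc1OC`: 27900 nM

Not yet measured: compound 3 `COc1ccc(-c2nc3ccc(F)cc3s2)cc1OC`.

Going by the values given here, compound 1 is the reference here, and compound 2, its only measured neighbour, lies within the scatter of it. The change under consideration is fluoro in place of hydrogen on an aromatic carbon of a six-membered aromatic ring of carbon only, part of a fused or bridged system of two rings. Among the compounds with values here, the one measured step that bears on it is the chloro replacement in compound 2, a 1.9-fold lower number from compound 1 to compound 2 (0.28 log units; within the scatter). This single step is small and gives thin support, so no step beyond the scatter is expected in this assay. The expected step is a 1.3-fold lower number from compound 1 to compound 3 (0.12 log units; within the scatter). For compound 3 the estimated value is 40000 nM, with an expected range of 15000 nM to 100000 nM.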

Compound 3, half-maximal inhibitory concentration: 62 nM
The estimate for compound 3 lay 650-fold (2.81 log units) above the measured number; measured number below the stated range.
By their numbers in this assay, from the lowest: compound 3; then compounds 2 and 1 (each within the scatter of the next).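

In this assay, fluoro in place of hydrogen on an aromatic carbon of the six-membered aromatic ring of carbon only gives an 850-fold lower number from compound 1 to compound 3 (2.93 log units; beyond the scatter), so one heavy atom at this place is enough to produce a large step on the core of compound 1. The chloro replacement gave only a 1.9-fold lower number from compound 1 to compound 2 (0.28 log units; within the scatter), so that step within the scatter did not show that a single replacement on the core could have an effect of this size. No measurement here bears on the reason for the step.

Compounds 2 and 3 differ in more than one place, so the part played by the halogen cannot be separated from the part played by its place. As far as these compounds go, whether chloro, an amine or a nitrile at the place of the fluoro in compound 3 would retain the low number remains open.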